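Acyclic dialkylamino in place of cyclobutylamino on the core

This account rests on a few compounds, and the source may have more. Where it says the series, first, only, none or still open, it means among the compounds named here.

Compound 2 `COc1ccc(-c2c(C)nn3c(NC4CCC4)nc(C)nc23)c(C)c1` gives 24.6 nM in an assay on cell membranes for displacement of a labelled ligand from corticotropin-releasing factor receptor 1 (Rattus norvegicus) (on this read-out lower numbers stand for stronger inhibition and higher numbers for weaker inhibition), the highest of the three numbers recorded in the series. Compound 1 `COCC(COC)Nc1nc(C)nc2c(-c3ccc(OC)cc3C)c(C)nn12` gives 9.7 nM and compound 3 `CCCC(C)Nc1nc(C)nc2c(-c3c(C)cc(OC)cc3OC)c(C)nn12` gives 2.14 nM. Compound 4 `CCCN(CCC#N)c1nc(C)nc2c(-c3ccc(OC)cc3C)c(C)nn12` carries (2-cyanoethyl)(propyl)amino in place of cyclobutylamino on an aromatic carbon, on the aromatic carbon between two ring nitrogen atoms. Within the data shown here, the only measured step touching this position is a 2.5-fold higher number from compound 1 to compound 2 (0.40 log units; beyond the scatter), a modest change. Among the measured compounds shown here, no measured pair exchanges a ring for an open chain at this position; the direction rests on compound 1, whose group there has no ring and which gives 9.7 nM, the lower number of that pair. A modest fall in the half-maximal inhibitory concentration is therefore expected, a 2.5-fold lower number from compound 2 to compound 4 (0.39 log units; beyond the scatter). Compound 4 is expected at 10 nM, with a range from 3 nM to 30 nM.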

Compound 4, half-maximal inhibitory concentration: 2.16 nM
Compound 4: middle estimate off by 4.6-fold (0.67 log units), on the high side; measured number outside the range, below it.
By their numbers in this assay, from the lowest: compounds 3 and 4 (each within the scatter of the next); then compound 1; then compound 2.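

In this assay, (2-cyanoethyl)(propyl)amino in place of cyclobutylamino gives an 11-fold lower number from compound 2 to compound 4 (1.06 log units; beyond the scatter), a large step and the first showing that this position can take a group with no hydrogen-bond donor. The same group in place of (2-methoxy-1-(methoxymethyl)ethyl)amino gives a 4.5-fold lower number from compound 1 to compound 4 (0.65 log units; beyond the scatter), so compound 1 does not mark the limit for open chains here. Nothing available explains either step.

Which part of the new group carries the change stays open. A dipropylamino group, with propyl in place of 2-cyanoethyl, would separate the nitrile from the chain.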